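The source may report more compounds than this note shows. Statements on the series, on what has been measured and on what is new or still open speak of the compounds shown alone.

Three compounds have numbers in a physicochemical assay for solubility, read by HPLC, in phosphate buffer, with a stated time of 4 h, at pH 7.4, tested at 10 mg/mL; on this read-out lower numbers stand for lower solubility and higher numbers for higher solubility. Compound 1 `Cc1cc(CCC#N)cc(C)c1Oc1cc(Nc2ccc(C#N)cc2)c(N)cc1CNC1CC1` gives 13.6 ug/mL, compound 2 `COCc1cc(N)c(Nc2ccc(C#N)cc2)cc1Oc1c(C)cc(CCC#N)cc1C` gives 0.66 ug/mL, and compound 3 `COC(=O)c1cc(N)c(Nc2ccc(C#N)cc2)cc1Oc1c(Br)cc(CCC#N)cc1OC` gives 0.2 ug/mL, the lowest of the three, with compound 2 nearest and compound 1 furthest. Compound 4 `CNC(=O)c1cc(N)c(Nc2ccc(C#N)cc2)cc1Oc1c(Br)cc(CCC#N)cc1OC` differs from compound 3 by methylamino in place of methoxy on a carbonyl carbon. Among the measured compounds shown here, the only single-point step measured here, a 21-fold lower number from compound 1 to compound 2 (1.31 log units; beyond the scatter), exchanged a group carrying a hydrogen-bond donor for a methoxy group and is large, but it sits on a chain carbon rather than a carbonyl carbon, so it bears on this change only loosely. A modest rise is expected for compound 4, with a 2.0-fold higher number from compound 3 to compound 4 (0.30 log units; within the scatter) as the estimated step. Compound 4 is therefore expected to give about 0.4 ug/mL, with a range from 0.15 ug/mL to 1.2 ug/mL.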

Compound 4, solubility: 3.38 ug/mL
The estimate for compound 4 lay 8.5-fold (0.93 log units) below the measured number; the whole stated range lies below it.
By their numbers in this assay, from the lowest: compound 3; then compound 2; then compound 4; then compound 1.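

On a carbonyl carbon, methylamino in place of methoxy gives a 17-fold higher number from compound 3 to compound 4 (1.23 log units; beyond the scatter) in this assay and this large step lies beyond the usual scatter. It is the only step shown at this carbonyl carbon, and it shows that exchanging two groups of equal heavy-atom count, neither with a ring or net charge, can shift this read-out strongly. Nothing measured here gives a reason for the step. The compounds shown leave open how dimethylamino, ethylamino or plain amino would read on this carbonyl carbon. They also leave open whether the step carries over to other substituents on the shared core.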